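Phenyl to benzyl on an amide-type nitrogen

The source may hold more compounds than are shown below. What is called first, only, known or untested is meant among the compounds shown, and "the series" means these compounds.

Values in an ADME assay on HepG2 cells (Homo sapiens), read by MTT assay, with a stated time of 72 h, in the presence of a further agent that is not named here; a higher number here means a weaker inhibitor, a lower number a stronger inhibitor:
- Compound 1 `O=C(NC1CCCCC1)Oc1ccccc1C(=O)Nc1ccccc1`: 51500 nM
- Compound 2 `O=C(Nc1ccccc1)Oc1ccccc1C(=O)Nc1ccccc1`: 26800 nM

In this assay, among the compounds with values here, compound 2 reads 26800 nM, which lies within the scatter of compound 1, the only other compound measured. The next compound is compound 3 `O=C(NCc1ccccc1)Oc1ccccc1C(=O)Nc1ccccc1`, still unmeasured. The change from compound 2 is benzyl in place of phenyl on an amide-type nitrogen. Within the data shown here, one measured step bears on it, at the same nitrogen: phenyl in place of cyclohexyl, a 1.9-fold lower number from compound 1 to compound 2 (0.28 log units; within the scatter). That single step stays within the scatter, so no step beyond the scatter is expected in this assay, in either direction. The expected change is a 1.3-fold higher number from compound 2 to compound 3 (0.12 log units; within the scatter). Compound 3 is estimated at 35000 nM, with an expected range of 15000 nM to 80000 nM.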

Compound 3, half-maximal inhibitory concentration: 54300 nM
For compound 3 the middle estimate is 1.6-fold (0.19 log units) below the measured one, within the range that was stated.
By their numbers in this assay, from the lowest: compounds 2, 1 and 3 (each within the scatter of the next, the first and the last beyond it).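

In this assay, this amide-type nitrogen gives its first step beyond the scatter, though only a modest one (a 2.0-fold higher number from compound 2 to compound 3 (0.31 log units; beyond the scatter)). Benzyl and cyclohexyl on this nitrogen read alike (a 1.1-fold higher number from compound 1 to compound 3 (0.02 log units; within the scatter)), while phenyl separates from benzyl but not from cyclohexyl (a 1.9-fold lower number from compound 1 to compound 2 (0.28 log units; within the scatter)), so the three groups do not fall into a clear order. No measurement shown accounts for the difference between phenyl and benzyl.

Still open, on these data alone, is how this nitrogen reads with a longer chain such as phenylethyl or with a small alkyl group such as methyl. Also open, as far as these compounds go, is whether an amine or a carboxylic acid on the phenyl ring of compound 3 would shift the number by more than this modest step.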